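Isopropoxy on an aromatic nitrogen: notes on compound 3

This account rests on a few compounds, and the source may have more. Where it says the series, first, only, none or still open, it means among the compounds named here.

Of the compounds shown here, two have been read so far in a functional assay on a cell-free system (plasma, Oryctolagus cuniculus) for inhibition, with stated times of 5 min, 1 min and 6 min; a lower number here means a stronger inhibitor, a higher number a weaker inhibitor. Compound 2 `CCOC(=O)c1[nH]c(-c2cccc(C#N)c2)nc1C` has no number in this assay. Compound 2 reads > 30000 nM, which is a limit of the assay and not a measured value. Compound 1 `CCOC(=O)c1c(C)nc(-c2ccccc2C#N)n1OC` gives a true number, and compound 1 reads 14900 nM.

The next compound is compound 3 `CCOC(=O)c1c(C)nc(-c2cccc(C#N)c2)n1OC(C)C`, which keeps the rest of compound 2 and changes one place: isopropoxy in place of hydrogen on an aromatic nitrogen. Isopropoxy replaces hydrogen on an aromatic nitrogen, next to the ring atom that bears an ethoxycarbonyl group.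

Among the measured compounds shown here, no measured pair isolates this change, so the expectation leans on one indirect comparison. Compound 1 also carries an oxygen-linked group on an aromatic nitrogen and reads 14900 nM, but it differs from compound 3 in more than that one place. A small step towards stronger inhibition in this assay is therefore expected, estimated as an at least 1.8-fold lower number from compound 2 to compound 3 (0.27 log units; that floor lies within the scatter). A reading that again gives only a limit remains possible. Compound 3 is estimated at 16000 nM, with an expected range of 6000 nM to 30000 nM.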

Compound 3, half-maximal inhibitory concentration: 6740 nM
For compound 3 the middle estimate is 2.4-fold (0.38 log units) above the measured one; the measured number falls inside the stated range.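

In this assay, among the compounds shown here, isopropoxy in place of hydrogen on an aromatic nitrogen goes with an at least 4.4-fold lower number from compound 2 to compound 3 (0.64 log units; beyond the scatter), the first step read between two compounds that differ in one place. For the compounds shown here, for compound 2 the reading of > 30000 nM is a limit of the assay and not a number, which makes this step a floor with no upper bound: the limit of > 30000 nM in this assay, at which 1 of the 3 values shown sits. What the pair adds is that this nitrogen, next to the ring atom that bears an ethoxycarbonyl group, can carry isopropoxy with a gain in inhibition that lies beyond the scatter, whereas compound 1 differs from compound 3 in more than one place and gives no step of its own.

Open, as far as these compounds go, is whether the oxygen link or the isopropyl carbons carry this step, and how a propyl chain attached directly to the aromatic nitrogen, or a longer alkoxy chain such as butoxy, would read in this assay. Also open, from the compounds shown here alone, is whether the gain would persist with a carboxylic acid in place of the ethoxycarbonyl group.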